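The source may hold more compounds than are shown below. What is called first, only, known or untested is meant among the compounds shown, and "the series" means these compounds.

In a functional assay on NCI/ADR-RES cells (Homo sapiens) for inhibition (a lower number here means a stronger inhibitor of growth, a higher number a weaker inhibitor of growth), compound 3 `O=C(NCCCNc1cc(-c2cn(-c3ccccc3)nc2-c2cccc(O)c2)ccn1)c1ccccc1` gives 9790 nM. Of the three numbers measured this is the highest, yet neither neighbour is separated from it by more than the scatter: compound 1 `COc1cccc(-c2nn(-c3ccccc3)cc2-c2ccnc(NCCNC(=O)Nc3cccc(C(F)(F)F)c3)c2)c1` gives 5750 nM, and compound 2 `COc1cccc(-c2nn(-c3ccccc3)cc2-c2ccnc(NCCCNC(=O)Nc3ccc(Cl)c(Cl)c3)c2)c1` gives 5390 nM, so the three compounds cannot be placed in any order on these values. Compound 4 `O=C(NCCCNc1cc(-c2cn(-c3ccccc3)nc2-c2cccc(O)c2)ccn1)c1ccc(F)cc1` differs from compound 3 in one place, (fluoro in place of hydrogen on an aromatic carbon), fluoro in place of hydrogen on an aromatic carbon. Among the measured compounds shown here, no pair of measured compounds differs in a single place, so no measured step is available to guide the expectation for this change. The step is expected to be a 1.1-fold lower number from compound 3 to compound 4 (0.04 log units; within the scatter), which is not beyond the scatter and carries no clear direction. Compound 4 is therefore estimated to give 9000 nM in this assay, with an expected range from 3500 nM to 23000 nM.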

Compound 4, concentration for total growth inhibition: 5820 nM
Compound 4: middle estimate off by 1.5-fold (0.19 log units), on the high side; measured number inside the range.
By their numbers in this assay, from the lowest: compounds 2, 1, 4 and 3 (each within the scatter of the next).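

Going from benzoyl to (4-fluorophenyl)carbonyl gives the first comparison in this assay between compounds that differ in one place, and it reads a 1.7-fold lower number from compound 3 to compound 4 (0.23 log units; within the scatter) for this single change. At this position, para to a large group, a fluoro in place of hydrogen therefore leaves the number within the usual scatter and gives no clear direction. No measurement at hand bears on the reason for this step.

On these data alone, it remains open whether a different group on the same aromatic carbon, such as chloro, methoxy or an amine, would give a step beyond the scatter. As far as these compounds go, it is also open whether fluoro would give a similar step with a longer chain in the linker or with methoxy in place of the hydroxy group of compound 3.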